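The source may hold more compounds than are shown below. What is called first, only, known or untested is meant among the compounds shown, and "the series" means these compounds.

Values from an ADME assay on Vero cells (Chlorocebus sabaeus) for antiproliferative activity, read by MTT assay, with a stated time of 72 h (on this read-out lower numbers stand for stronger inhibition and higher numbers for weaker inhibition), follow, both of them limits and not numbers:
- compound 1 `CN(c1ccc(Cl)cc1)S(=O)(=O)C1CC2OC1C(c1ccc(NC(=O)CCCCCCC(=O)O)cc1)=C2c1ccc(O)cc1` gives > 100000 nM as a limit
- compound 2 `CCN(c1ccc(OC)cc1)S(=O)(=O)C1CC2OC1C(c1ccc(NC(=O)CCCCCCC(=O)O)cc1)=C2c1ccc(O)cc1` gives > 100000 nM as a limit

Compound 2 has only the limit > 100000 nM on record. Compound 3 `CCN(c1ccccc1Cl)S(=O)(=O)C1CC2OC1C(c1ccc(NC(=O)CCCCCCC(=O)O)cc1)=C2c1ccc(O)cc1` brings 2-chlorophenyl in place of 4-methoxyphenyl on a sulfonamide nitrogen, counted as 2-chlorophenyl in place of 4-methoxyphenyl on a sulfonamide nitrogen in the change from compound 2. Among the measured compounds shown here, the one measured step is a step that the two limits leave unreadable from compound 1 to compound 2 and gives no size to carry over. For the measured compounds named here, with compound 1 and compound 2 both at the limit of > 100000 nM in this assay, at which 2 of the 2 values shown sit, as the only guide, no step beyond the scatter is expected in this assay for this change. The estimated step is a number no higher from compound 2 to compound 3 (the limit leaves the size open) in this reading. Compound 3 is estimated at 100000 nM with a range from 40000 nM to 200000 nM and a limit is the likely report.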

Compound 3, half-maximal inhibitory concentration: > 100000 nM
Compound 3: only a limit was reported; the forecaster's own chance of this, stated with the estimate: 85%; the middle value lies on the limit itself.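

In this assay no step can be read among compound 1, compound 2 and compound 3, since all three values are limits: the limit of > 100000 nM in this assay, at which 3 of the 3 values shown sit.

The compounds shown leave open where any true value lies and whether changing the groups on the sulfonamide nitrogen shifts it.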